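Removing the methyl group: from compound 3 to compound 4

The compounds below may be only part of what the source reports. "The series", "measured", "known", "first", "only" and "open" are said of these compounds alone.

Measured so far:
compound 1 `O=C(CCCCCCNCc1ccc([N+](=O)[O-])cc1)NO` — 2100 nM
compound 2 `O=C(CCCCCCN(Cc1cc2ccccc2[nH]1)Cc1cc2ccccc2[nH]1)NO` — 4600 nM
compound 3 `Cc1cc(CNCCCCCCC(=O)NO)ccc1F` — 2800 nM

All three were tested in an assay on cells for inhibition of histone deacetylase 8 (Homo sapiens), read by fluorescence, with a stated time of 24 h; a lower number here means a stronger inhibitor, a higher number a weaker inhibitor. Compound 3 stands second highest of the three numbers; its nearest neighbour is compound 1 and its furthest is compound 2, and both gaps lie within the scatter, so the three cannot be separated.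

Compound 4 `O=C(CCCCCCNCc1ccc(F)cc1)NO` has not been measured. It differs from compound 3 by hydrogen in place of methyl on an aromatic carbon. For the measured compounds named here, no pair of measured compounds differs by this change alone, so no measured precedent exists. The step is expected to be a 1.1-fold higher number from compound 3 to compound 4 (0.03 log units; within the scatter), in no firm direction and not beyond the scatter. Compound 4 is therefore estimated at 3000 nM, between 1400 nM and 6500 nM.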

Compound 4, half-maximal inhibitory concentration: 1700 nM
Estimate against measurement, compound 4: 1.8-fold (0.25 log units) above; the measured number falls inside the stated range.
By their numbers in this assay, from the lowest: compounds 4, 1, 3 and 2 (each within the scatter of the next, the first and the last beyond it).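

In this assay, for the compounds shown here, the methyl group ortho to a fluoro group can be replaced by hydrogen with a step that stays within the scatter (a 1.6-fold lower number from compound 3 to compound 4 (0.22 log units; within the scatter)), the first reading of any change at this position. Fluoro in place of nitro on an aromatic carbon also stays within the scatter (a 1.2-fold lower number from compound 1 to compound 4 (0.09 log units; within the scatter)), so neither change separates its pair of compounds. Nothing measured here gives a reason for either step. Still open, as far as these compounds go, is whether an amine, a carboxylic acid or a longer chain on that aromatic carbon would move the number beyond the scatter.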